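Solubility notes: aryl substituent changes at the bicyclic core

The source may report more compounds than this note shows. Statements on the series, on what has been measured and on what is new or still open speak of the compounds shown alone.

Measured compounds:
compound 1, `COc1cccc(CNCCCNc2ccnc3cc(Cc4cc(C)cc(C)c4)ccc23)c1O`, 4200 nM
compound 2, `COc1cccc(CNCCCNc2ccnc3cc(Oc4ccc(F)cc4)ccc23)c1O`, 14500 nM
compound 3, `COc1ccccc1Oc1ccc2c(NCCCNCc3cccc(OC)c3O)ccnc2c1`, 14500 nM

In a physicochemical assay for solubility, with a stated time of 18 h, at pH 7.4 (a lower number here means a less soluble compound, a higher number a more soluble compound), compound 3 stands level with compound 2 at the digits shown, the two together the highest of the three numbers; the step of no change at the digits printed from compound 2 to compound 3 (within the scatter) lies within the scatter. Against compound 1 the gap is real: a 3.5-fold higher number from compound 1 to compound 3 (0.54 log units; beyond the scatter). Compound 4, `COc1cccc(CNCCCNc2ccnc3cc(-c4cccc5ccccc45)ccc23)c1O`, has not yet been measured. It differs from compound 3 as follows: naphthalen-1-yl in place of 2-methoxyphenoxy on an aromatic carbon.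

Going by the values given here, the steps that bear on this change are those at the same aromatic carbon, a 3.5-fold higher number from compound 1 to compound 2 (0.54 log units; beyond the scatter) and a 3.5-fold higher number from compound 1 to compound 3 (0.54 log units; beyond the scatter), both modest and both beyond the scatter, where a benzyl group was exchanged for a phenoxy group. Among the compounds with values here, compound 4 carries neither a benzyl nor a phenoxy group but naphthalen-1-yl, so no measured step matches it directly. A downward step beyond the scatter is nevertheless expected, a 4.8-fold lower number from compound 3 to compound 4 (0.68 log units; beyond the scatter), roughly undoing the gap seen between compound 1 and compound 3. Compound 4 is estimated at 3000 nM, with a range of 1000 nM to 9000 nM.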

Compound 4, solubility: 32000 nM
For compound 4 the middle estimate is 11-fold (1.03 log units) below the measured one; measured number outside the range, above it.
By their numbers in this assay, from the lowest: compound 1; then compounds 2 and 3 (each within the scatter of the next); then compound 4.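

At this aromatic carbon of the shared core, this assay shows that the phenoxy groups do not mark the top of the series: naphthalen-1-yl gives a 2.2-fold higher number from compound 3 to compound 4 (0.34 log units; beyond the scatter) and a 2.2-fold higher number from compound 2 to compound 4 (0.34 log units; beyond the scatter). Against 3,5-dimethylbenzyl the step is wider, a 7.6-fold higher number from compound 1 to compound 4 (0.88 log units; beyond the scatter), so an oxygen joining the aryl group to this carbon is not required for a high number; compound 1 also lacks that oxygen and sits lowest, so its absence alone does not sort the series. Nothing measured here accounts for this order.

From the compounds shown here alone, whether a plain phenyl, an amine or a carboxylic acid on this carbon would follow naphthalen-1-yl remains open. So does whether the order among these groups would hold with a longer chain in place of the present linker.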